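From methoxy to butoxy at the assay limit

The compounds below may be only part of what the source reports. "The series", "measured", "known", "first", "only" and "open" are said of these compounds alone.

Compound 1 `CC(=O)Oc1ccccc1/C=C/c1nc2ccccc2c(=O)[nH]1`: > 25000 nM (a limit)
Compound 2 `COc1ccc(OC)c(Nc2nc(/C=C/c3ccccc3OC(C)=O)nc3ccccc23)c1`: > 25000 nM (a limit)
Compound 3 `COc1ccc(/C=C/c2nc3ccccc3c(=O)[nH]2)cc1`: > 25000 nM (a limit)

All three compounds were tested in a functional assay on HCT-116 cells (Homo sapiens) for antiproliferative activity, with a stated time of 72 h (on this read-out lower numbers stand for stronger inhibition and higher numbers for weaker inhibition), and none has yet given a number. The record so far is the limit of > 25000 nM in this assay, at which 3 of the 3 values shown sit. In this assay compound 3 stands at > 25000 nM, which is a limit of the assay and not a number.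

Compound 4 `CCCCOc1ccc(/C=C/c2nc3ccccc3c(=O)[nH]2)cc1` differs from compound 3 by propyl in place of hydrogen on a saturated chain carbon bound to an oxygen on an aromatic ring, so methoxy becomes butoxy. Going by the values given here, no step between measured compounds gives a size for this change. No step beyond the scatter is therefore expected in this assay, in either direction, and a further limit is the likeliest report. The expected step is a number no higher from compound 3 to compound 4 (the limit leaves the size open). For compound 4 the estimated value is 25000 nM, with an expected range from 8000 nM to 60000 nM.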

Compound 4, half-maximal inhibitory concentration: > 25000 nM
Compound 4 ended at the assay's limit (the forecaster's own chance of this, stated with the estimate: 60%); the middle value sits exactly at the limit.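

No step can be read from compound 3 to compound 4, because both values are limits of the assay and not numbers: the limit of > 25000 nM in this assay, at which 4 of the 4 values shown sit.

The compounds shown leave open whether butoxy in place of methoxy changes the activity at all, since none of them yet gives a number.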